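Removing the amine substituent on a shared core

A few compounds are considered here, and "the series" means these few. Any claim that something is new, unique, unknown or untested is made for them only; others in the source may bear on it.

Measured compounds:
- compound 1, `N#CC1=C(NCC(=O)N2CCCC2)N(c2ccccc2)C(=O)N2CCCCC(N3CCCC3)C12`: 49.8%
- compound 2, `N#CC1=C(NC(=O)c2ccccc2O)N(c2ccccc2)C(=O)N2CCCCC(N3CCCC3)C12`: 53.8%

In a functional assay on the whole organism (strain albino) for inhibition, with Rattus norvegicus as the target, read by paw edema, with stated times of 1 h and 2 h, at a dose of 20 mmol/kg by the intraperitoneal route (on this read-out lower numbers stand for less inhibition and higher numbers for more inhibition at the one dose given (going by the name of the read-out)), compound 1 gives 49.8%. Among the compounds with values here, compound 2, the only other compound measured, gives 53.8% in this assay; the two numbers sit within the scatter of each other, and the step of a number 4 percentage points higher from compound 1 to compound 2 (within the scatter) says nothing more than that.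

Compound 3 is `N#CC1=C(N)N(c2ccccc2)C(=O)N2CCCCC(N3CCCC3)C12`. It differs from compound 1 in one place: hydrogen in place of ((pyrrolidin-1-yl)carbonyl)methyl on an amine nitrogen. The amine nitrogen that carries a ((pyrrolidin-1-yl)carbonyl)methyl group in compound 1 carries only a hydrogen in compound 3.

Within the data shown here, the single measured step bears on this change only loosely. Among the measured compounds shown here, it replaces one substituent on that amine nitrogen with another, (2-hydroxyphenyl)carbonyl, and is within the scatter; no measured step removes the substituent altogether. For the measured compounds named here, the two numbers available therefore suggest that what sits on this nitrogen has not moved the read-out in this assay so far, and compound 3 is expected to show a step of a number 4.8 percentage points lower from compound 1 to compound 3 (within the scatter), with no change beyond the scatter predicted but with the uncertainty of an untested kind of change. Compound 3 is estimated at 45% in this assay, within a range of 25% to 65%.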

Compound 3, a percentage reported as inhibition, in the whole organism at one dose (the size of the read-out at that dose, not a potency): 86.9%
The estimate for compound 3 lay 41.9 percentage points below the measured number, outside the stated range (above it).
By their numbers in this assay, from the lowest: compounds 1 and 2 (each within the scatter of the next); then compound 3.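

In this assay, taking the substituent off the amine nitrogen altogether gives a number 37.1 percentage points higher from compound 1 to compound 3 (beyond the scatter) and not the small shift the earlier pair had suggested, while removing (2-hydroxyphenyl)carbonyl from the same nitrogen gives a number 33.1 percentage points higher from compound 2 to compound 3 (beyond the scatter). The position therefore matters in this read-out: the two substituted compounds, which carry quite different groups, lie within the scatter of each other, and the plain amino group stands well apart from both. The compounds shown offer no measurement that accounts for this difference.

They leave open whether any group on this nitrogen brings the number down or only groups as large as the two tested here do, a question that a single methyl or an acetyl group in place of the hydrogen would begin to answer. It also remains open whether a short chain ending in an amine or a carboxylic acid would stay close to compound 3 or fall back to the level of compound 1, and how any of these compounds would behave at other doses.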